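A few compounds are considered here, and "the series" means these few. Any claim that something is new, unique, unknown or untested is made for them only; others in the source may bear on it.

In a physicochemical assay for lipophilicity, using the shake flask method, at pH 7.4 (a lower number here means a more polar compound, a higher number a more lipophilic compound), compound 1 (`O=C(O)CCNC(=O)c1ccc(C(Oc2ccc(-n3cc(C(F)(F)F)cn3)cc2)C2CC2)cc1`) gives 1.7. Among the measured compounds shown here, this is the middle of the three numbers so far, since compound 2 (`CCCC(Oc1ccc(-n2cc(C#N)cn2)cc1)c1ccc(C(=O)NCCC(=O)O)cc1`) gives 1.2 and compound 3 (`CCCC(Oc1ccc(-n2cc3c(n2)CCCC3)cc1)c1ccc(C(=O)NCCC(=O)O)cc1`) gives 2.7. Compound 4 (`CC(C)(C)C(Oc1ccc(-n2cc(C(F)(F)F)cn2)cc1)c1ccc(C(=O)NCCC(=O)O)cc1`) has not yet been measured. It carries tert-butyl in place of cyclopropyl on a saturated chain carbon bound to an aromatic carbon and an oxygen on an aromatic ring.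

For the measured compounds named here, no measured step involves a change at that carbon. Going by the values given here, the only single-place step available is a number 1.50 log units higher from compound 2 to compound 3 (beyond the scatter), and it comes from a change elsewhere in the molecule, so it is only a loose guide. There, a larger group came in and the number went up. The swap in compound 4 is far smaller, so a modest move in the same direction is expected, a number 0.40 log units higher from compound 1 to compound 4 (beyond the scatter). For compound 4 the estimated value is 2.1, with a range of 1.7 to 2.5.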

Compound 4, distribution coefficient: 3.7
For compound 4 the middle estimate is 1.60 log units below the measured one; measured number above the stated range.
By their numbers in this assay, from the lowest: compound 2; then compound 1; then compound 3; then compound 4.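

Putting tert-butyl in place of cyclopropyl on this saturated chain carbon gives, in this assay, a number 2.00 log units higher from compound 1 to compound 4 (beyond the scatter). Among the compounds shown here, this is the first measured change at this carbon, and it shows that the number can move by a large step even though the swap is small on paper: both groups are all carbon, with no hydrogen-bond donors or acceptors on either group. No measurement shown here gives a reason for a step of this size.

The compounds shown leave open whether the step goes with the loss of the ring or with the extra carbon. Isopropyl or cyclobutyl on the same carbon, with the rest of compound 1 unchanged, would help to separate these two possibilities.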